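The source may hold more compounds than are shown below. What is called first, only, known or untested is meant among the compounds shown, and "the series" means these compounds.

Compound 1 `O=C1C(=O)N(Cc2ccc(-c3cccnc3)cc2)c2ccc(OC(F)(F)F)cc21` gave 51% in a functional assay on CHO cells for positive allosteric modulation of muscarinic acetylcholine receptor M5 (Homo sapiens), read by FLIPR and calcium flux, with a stated time of 1 h; on this read-out higher numbers stand for larger maximal responses and lower numbers for smaller maximal responses.
Compound 2 `O=C1C(=O)N(Cc2ccc(-c3ccccc3)nc2)c2ccc(OC(F)(F)F)cc21` gave 76% in this assay.

Of the two numbers, compound 1 stands lowest; compound 2 lies above it by a margin beyond the usual scatter of this kind of measurement. Within the data shown here, no step between two measured compounds that differ in a single place is available, so the shift from compound 1 to compound 2 can only be read as what those two values show, without being traced to one change.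

Compound 3 `O=C1C(=O)N(Cc2ccc(-c3ccncc3)cc2)c2ccc(OC(F)(F)F)cc21` has not yet been measured in this assay. It differs from compound 1 as follows: pyridin-4-yl in place of pyridin-3-yl on an aromatic carbon. Among the measured compounds shown here, since the two have the same atoms joined differently, and no measured step of this kind exists among the compounds at hand, the size of the change is uncertain. A step of modest size is expected, without a firm direction, with a shift small enough to fall near the scatter, a number 4 percentage points higher from compound 1 to compound 3 (within the scatter). Compound 3 is therefore estimated at 55%, within a range from 35% to 80%.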

Compound 3, largest response reached (Emax), in percent of the reference or control that the assay uses: 60%
Estimate against measurement, compound 3: 5 percentage points below; low and high end bracket the measured number.
By their numbers in this assay, from the lowest: compounds 1 and 3 (each within the scatter of the next); then compound 2.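

In this assay, among these compounds, the change from pyridin-3-yl to pyridin-4-yl, on an aromatic carbon para to a large group, gives the first step in this set that can be read at a single place: a number 9 percentage points higher from compound 1 to compound 3 (within the scatter). The two groups have the same atoms, joined differently, so the step concerns only where the ring nitrogen stands, and at this position the two placements cannot be told apart on this read-out. Nothing measured here speaks to why the two compounds fall so close together.

The compounds shown leave open whether a pyridin-2-yl group at this same carbon would also stay within the scatter of compound 1, and whether an amine or a carboxylic acid on the pyridine ring would move the maximal response beyond it. No compound shown differs from compound 2 in one place only, so its value of 76% remains untraced to any single change.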